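The source may hold more compounds than are shown below. What is called first, only, known or untested is meant among the compounds shown, and "the series" means these compounds.

Compound 1 `COc1ccc(CN(C(=O)CSC(=S)N2CCN(C(=O)OC(C)(C)C)CC2)c2ccc(Br)cc2)cc1`: in a functional assay on MGC-803 cells (Homo sapiens) for inhibition, read by CCK-8 assay, with a stated time of 48 h (on this read-out lower numbers stand for stronger inhibition and higher numbers for weaker inhibition), compound 1 gives > 20000 nM, which is a limit of the assay rather than a number.
Compound 2 `COc1ccc(CN(C(=O)CSC(=S)N2CCN(C(=O)OC(C)(C)C)CC2)c2ccc(C)cc2)cc1`: in this assay compound 2 gives > 20000 nM, again a limit.
Compound 3 `COc1ccc(CN(C(=O)CSC(=S)N2CCN(C(=O)OC(C)(C)C)CC2)c2cc(OC)c(OC)c(OC)c2)cc1Br`: in this assay compound 3 gives 3710 nM.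

Only compound 3 returns a number; the other two values sit at the limit of > 20000 nM in this assay, at which 2 of the 3 values shown sit. The change from compound 1 to compound 2 is methyl in place of bromo on an aromatic carbon, and its step, a step that the two limits leave unreadable from compound 1 to compound 2, cannot be read because both ends are limits. The difference between the core of compound 1 and the core of compound 3 is not broken down here.

Compound 4 `COc1ccc(CN(C(=O)CSC(=S)N2CCN(C(=O)OC(C)(C)C)CC2)c2cc(OC)c(OC)c(OC)c2)cc1C` has not been measured. It differs from compound 3 by methyl in place of bromo on an aromatic carbon, the same kind of change as from compound 1 to compound 2, though here the place is ortho to a methoxy group and meta to a large group, whereas in compound 2 it is para to a large group. With the earlier step unreadable, the expectation rests only on compound 3 and its value 3710 nM: the step of a 1.3-fold higher number from compound 3 to compound 4 (0.13 log units; within the scatter) is expected to be small. Compound 4 is therefore estimated at 5000 nM in this assay, between 1500 nM and 16000 nM.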

Compound 4, half-maximal inhibitory concentration: > 20000 nM
Compound 4 gave a limit, no number (the forecaster's own chance of this, stated with the estimate: 15%); at least 4.0-fold (0.60 log units) between middle value and limit.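

In this assay, methyl in place of bromo on the 3-bromo-4-methoxybenzyl group weakens inhibition on the core of compound 3, giving an at least 5.3-fold higher number from compound 3 to compound 4 (0.73 log units; beyond the scatter). The same kind of change on the core of compound 1 cannot be read, with limits at both ends and at a different place, so this single readable step shows what the change does on one core only and does not show that it carries from one core to another. Compound 4 gives a limit and not a number, like compound 1 and compound 2, so the true size of its step stays unknown: the limit of > 20000 nM in this assay, at which 3 of the 4 values shown sit.

From the compounds shown here alone, whether chloro, a nitrile or an amine in the place of the bromo would keep inhibition near that of compound 3, which gives 3710 nM, stays open. Also open, going by these compounds, is whether ethyl or a longer chain there would behave as methyl does, on this core or on any other.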